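A few compounds are considered here, and "the series" means these few. Any claim that something is new, unique, unknown or untested is made for them only; others in the source may bear on it.

Of the compounds shown here, two have been measured in a functional assay on CHO-K1 cells for agonist activity at Glucose-dependent insulinotropic receptor (Homo sapiens), read by a luciferase reporter, with a stated time of 5 h; a higher number here means that more compound is needed for the effect, a lower number that less compound is needed. Compound 1, `CC(C)(C)OC(=O)N1CCC(Oc2cccc3c2ccn3-c2ccc(S(C)(=O)=O)cc2)CC1`, gives 631 nM. Compound 2, `CCCCOC(=O)N1CCC(Oc2ncnc3c2CCN3c2ccc(S(C)(=O)=O)cc2F)CC1`, gives 50.1 nM, the lower of the two numbers; compound 1 sits well above it, beyond the usual scatter. The next compound, compound 3, is `CCS(=O)(=O)N1CCC(Oc2ncnc3c2CCN3c2ccc(S(C)(=O)=O)cc2F)CC1`. Among the measured compounds shown here, its single change from compound 2 is ethylsulfonyl in place of butoxycarbonyl on an amine nitrogen in a ring. For the measured compounds named here, no measured pair shows this exact swap, so the step from compound 2 to compound 3 is expected to be small, perhaps a modest rise, as a 2.0-fold higher number from compound 2 to compound 3 (0.30 log units; within the scatter). Compound 3 is thus estimated at 100 nM, with a range from 30 nM to 400 nM.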

Compound 3, half-maximal effective concentration: 1580 nM
Compound 3: the middle estimate sits 16-fold (1.20 log units) below what was measured; measured number outside the range, above it.
By their numbers in this assay, from the lowest: compound 2; then compound 1; then compound 3.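

On the amine nitrogen of the six-membered ring, the choice of group matters a great deal: ethylsulfonyl in place of butoxycarbonyl gives a 32-fold higher number from compound 2 to compound 3 (1.50 log units; beyond the scatter), with the rest of the molecule unchanged. The two groups have equal counts of hydrogen-bond donors and acceptors, so those counts alone do not set the number at this position. No measurement at hand explains the rise. On these data alone, the swap alters both the chain and the linking unit, so which of them counts stays open. Butylsulfonyl or ethoxycarbonyl on this nitrogen would separate the two.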